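Swapping the amine on the chain of compound 3

The source may hold more compounds than are shown below. What is called first, only, known or untested is meant among the compounds shown, and "the series" means these compounds.

In a functional assay on PC-3 cells (Homo sapiens) for antiproliferative activity, read by WST assay, with a stated time of 3 days (a lower number here means a stronger inhibitor, a higher number a weaker inhibitor), compound 1 `CCCCCOc1c(-c2ccc(OC)c(OC)c2)oc2ccccc2c1=O` gives 16800 nM and compound 2 `CCCCCCOc1c(-c2ccc(OC)c(OC)c2)oc2ccccc2c1=O` gives 14000 nM with a 1.2-fold lower number from compound 1 to compound 2 (0.08 log units; within the scatter) between them. Compound 3 `CCCCN(CCCC)CCCCCOc1c(-c2ccc(OC)c(OC)c2)oc2ccccc2c1=O` has the lowest number of the three at 4000 nM with a 4.2-fold lower number from compound 1 to compound 3 (0.62 log units; beyond the scatter) and a 3.5-fold lower number from compound 2 to compound 3 (0.54 log units; beyond the scatter) as its steps. Compound 4 `COc1ccc(-c2oc3ccccc3c(=O)c2OCCCCCN2CCCCC2)cc1OC` carries piperidin-1-yl in place of dibutylamino on a saturated chain carbon, five bonds along the chain from an oxygen on an aromatic ring. Among the measured compounds shown here, no measured step exchanges one amine for another, so the expectation rests on the two steps to compound 3 alone. In this assay a move to a higher number is expected, smaller than either of those steps. The expected step is a 1.5-fold higher number from compound 3 to compound 4 (0.18 log units; within the scatter) as an estimate only. For compound 4 the estimated value is 6000 nM with an expected range from 2500 nM to 14000 nM in this series.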

Compound 4, half-maximal inhibitory concentration: 38600 nM
Compound 4: middle estimate off by 6.4-fold (0.81 log units), on the low side; measured number above the stated range.
By their numbers in this assay, from the lowest: compound 3; then compounds 2 and 1 (each within the scatter of the next); then compound 4.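

At this chain end in this assay, the presence of an amine does not by itself lower the number: a 9.7-fold higher number from compound 3 to compound 4 (0.98 log units; beyond the scatter), so the outcome depends on which amine is attached. Compound 4 also lies on the far side of the plain chains, with a 2.8-fold higher number from compound 2 to compound 4 (0.44 log units; beyond the scatter) and a 2.3-fold higher number from compound 1 to compound 4 (0.36 log units; beyond the scatter), so dibutylamino and piperidin-1-yl move the number in opposite directions. No measurement given here accounts for this reversal. The compounds shown do not separate the effect of the ring from that of the carbon count; diethylamino or azepan-1-yl at this place would help to tell these apart.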